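A few compounds are considered here, and "the series" means these few. Any claim that something is new, unique, unknown or untested is made for them only; others in the source may bear on it.

Measured so far:
compound 1, `C[C@@H]1CCN(c2cc(-c3ccccc3)nc3ncnn23)C[C@@H]1N(C)c1ncnc2[nH]ccc12`: > 100000 nM
compound 2, `Cc1nc2nc(SCc3ccc(Cl)cc3)nn2c(N2CC[C@@H](C)[C@@H](N(C)c3ncnc4[nH]ccc34)C2)c1C`: 99200 nM
compound 3, `Cc1cc(N2CC[C@@H](C)[C@@H](N(C)c3ncnc4[nH]ccc34)C2)n2nc(SCCc3ccccc3)nc2n1`: 66200 nM

All three compounds share one core and were tested in a toxicity assay on GES1 cells (Homo sapiens) for inhibition, read by MTT assay, with a stated time of 72 h; a lower number here means a stronger inhibitor, a higher number a weaker inhibitor. For compound 1 the value > 100000 nM is a limit of the assay, not a number; (the limit of > 100000 nM in this assay, at which 1 of the 3 values shown sits). Compound 2 gives 99200 nM. Compound 3 gives 66200 nM, the lowest of the two numbers, though its gap to compound 2 lies within the scatter, so the two cannot be ordered. Compound 4, `Cc1cc(N2CC[C@@H](C)[C@@H](N(C)c3ncnc4[nH]ccc34)C2)n2nc(SCc3ccc([N+](=O)[O-])cc3)nc2n1`, has not yet been measured. It differs from compound 3 in one place: 4-nitrophenyl in place of benzyl on a saturated chain carbon bound to a sulfur. Among the compounds with values here, no step between two measured compounds is known, so the size of this change can only be expected, and the expected step is one not beyond the scatter: a 1.1-fold higher number from compound 3 to compound 4 (0.02 log units; within the scatter). Compound 4 is estimated at 70000 nM, between 30000 nM and 150000 nM.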

Compound 4, half-maximal inhibitory concentration: 36600 nM
Estimate against measurement, compound 4: 1.9-fold (0.28 log units) above; the range from low to high includes it.
By their numbers in this assay, from the lowest: compounds 4, 3 and 2 (each within the scatter of the next, the first and the last beyond it). At a limit, above all of these: compound 1.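

Within the data shown here, replacing benzyl with 4-nitrophenyl on a saturated chain carbon bound to a sulfur gives the first step that can be read at this place in this assay: a 1.8-fold lower number from compound 3 to compound 4 (0.26 log units; within the scatter). The swap of phenethyl for 4-nitrobenzyl therefore does not move the value past the scatter, so the two compounds cannot be ordered. Compound 1 remains a limit, not a number: the limit of > 100000 nM in this assay, at which 1 of the 4 values shown sits.

The compounds shown leave open whether an amine or a carboxylic acid in place of 4-nitrophenyl would give a step beyond the scatter. They also leave open what a longer chain at this place would do.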